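The source may hold more compounds than are shown below. What is called first, only, known or untested is meant among the compounds shown, and "the series" means these compounds.

Measured in an assay on MCF7 cells for inhibition of Serine-protein kinase ATM (Homo sapiens), read by immunofluorescence, with a stated time of 1 h; a lower number here means a stronger inhibitor, a higher number a weaker inhibitor:
compound 1 `COCCOc1cc2c(-n3nc(-c4ccccn4)nc3N)ncnc2cc1OC` gives 1200 nM
compound 2 `COc1cc2ncnc(-n3nc(-c4ccccn4)nc3N)c2cc1OCCCNC(=O)OC(C)(C)C` gives 900 nM
compound 3 `COc1cc2ncnc(-n3nc(-c4ccccn4)nc3N)c2cc1OCCNC(=O)OC(C)(C)C` gives 800 nM

Compound 3 sits within the scatter of both compound 2 and compound 1, so the three cannot be separated on these numbers. Compound 4 `COc1cc2ncnc(-n3nc(-c4ccccn4)nc3N)c2cc1OCCCNC(=O)OC(C)C` differs from compound 3 by ((isopropoxycarbonyl)amino)methyl in place of (tert-butoxycarbonyl)amino on a saturated chain carbon, two bonds along the chain from an oxygen on an aromatic ring. The measured steps that bear on this are a 1.5-fold lower number from compound 1 to compound 3 (0.18 log units; within the scatter), a 1.3-fold lower number from compound 1 to compound 2 (0.12 log units; within the scatter) and a 1.1-fold lower number from compound 2 to compound 3 (0.05 log units; within the scatter); every change made so far on this chain has left this assay inside the scatter. Exchanging one carbamate for another on the same chain is therefore expected to give no step beyond the scatter. Compound 4 is estimated at 900 nM (range 450 nM to 1800 nM), which corresponds to an expected 1.1-fold higher number from compound 3 to compound 4 (0.05 log units; within the scatter).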

Compound 4, half-maximal inhibitory concentration: 1000 nM
The estimate for compound 4 lay 1.1-fold (0.05 log units) below the measured number; measured number inside the range.
By their numbers in this assay, from the lowest: compounds 3, 2, 4 and 1 (each within the scatter of the next).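

In this assay, isopropoxycarbonyl in place of tert-butoxycarbonyl on the same propoxy chain gives a 1.1-fold higher number from compound 2 to compound 4 (0.05 log units; within the scatter), and the change from 2-((tert-butoxycarbonyl)amino)ethoxy to 3-((isopropoxycarbonyl)amino)propoxy gives a 1.3-fold higher number from compound 3 to compound 4 (0.10 log units; within the scatter). With a 1.2-fold lower number from compound 1 to compound 4 (0.08 log units; within the scatter) also within the scatter, the alkyl end of the carbamate now joins chain length and the replacement of methoxy as changes that these numbers do not resolve. No evidence is available on the reason for these small steps.

Going by these compounds, whether a free amine, a carboxylic acid or a longer chain at this position would give a step beyond the scatter remains open.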